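The source may hold more compounds than are shown below. What is called first, only, known or untested is meant among the compounds shown, and "the series" means these compounds.

Going by the values given here, compound 1 `O=C(Nc1cccc(-c2oc3cc(-c4ccc(F)cc4)ccc3c(=O)c2O)c1)c1ccc(F)cc1` gives 6930 nM in a functional assay on A549 cells (Homo sapiens) for antiproliferative activity, read by CCK-8 assay, with a stated time of 72 h (on this read-out lower numbers stand for stronger inhibition and higher numbers for weaker inhibition), the lowest of the two numbers known. Among the compounds with values here, its companion, compound 2 `O=C(Nc1cccc(-c2oc3cc(-c4ccc(F)cc4)ccc3c(=O)c2O)c1)c1cccc(F)c1`, gives 15400 nM in this assay, and the step of a 2.2-fold higher number from compound 1 to compound 2 (0.35 log units; beyond the scatter) is the only measured comparison. Compound 3 `CCCc1ccc(C(=O)Nc2cccc(-c3oc4cc(-c5ccc(F)cc5)ccc4c(=O)c3O)c2)cc1` differs from compound 1 as follows: propyl in place of fluoro on an aromatic carbon. Within the data shown here, no measured step tests a swap of this kind; the single known step concerns only the position of the fluoro and was modest. A step of no more than modest size is therefore expected, in either direction, and compound 3 is estimated at 5500 nM, between 1800 nM and 17000 nM, a step of a 1.3-fold lower number from compound 1 to compound 3 (0.10 log units; within the scatter).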

Compound 3, half-maximal inhibitory concentration: 47600 nM
Compound 3: the middle estimate sits 8.7-fold (0.94 log units) below what was measured, and the stated range ends below it.
By their numbers in this assay, from the lowest: compound 1; then compound 2; then compound 3.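

In this assay, propyl in place of fluoro gives a 6.9-fold higher number from compound 1 to compound 3 (0.84 log units; beyond the scatter), and 4-propylphenyl in place of 3-fluorophenyl gives a 3.1-fold higher number from compound 2 to compound 3 (0.49 log units; beyond the scatter). This ring position therefore responds to the identity of its group as well as to where the fluoro sits, and compound 3 is the weakest of the three. Nothing available explains this loss. Still open, as far as these compounds go, is whether a smaller methyl, a longer butyl chain or an amine at the same place would match compound 1, and whether activity falls steadily with chain length.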